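The source may hold more compounds than are shown below. What is called first, only, known or untested is meant among the compounds shown, and "the series" means these compounds.

In an in vivo ADME assay on the whole organism (strain 129/SvEvBrd x C57BL/6) for pharmacokinetics, with Mus musculus as the target (a lower number here means that a smaller share of the oral dose reaches the circulation, a higher number that a larger share of the oral dose reaches the circulation), three compounds sharing one core have been measured. Compound 1 `OC[C@@H](O)[C@@H](O)[C@H](O)c1c[nH]c(-c2ncc[nH]2)n1` gives 28%, compound 2 `OC[C@@H](O)[C@@H](O)[C@H](O)c1c[nH]c(-c2ncccn2)n1` gives 7%, and compound 3 `OC[C@@H](O)[C@@H](O)[C@H](O)c1c[nH]c(-c2cnccn2)n1` gives 10%. Compound 3 therefore lies within the scatter of compound 2 and well short of compound 1.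

The step now in question leads to compound 4 `OC[C@@H](O)[C@@H](O)[C@H](O)c1c[nH]c(-c2ncon2)n1`: 1,2,4-oxadiazol-3-yl in place of pyrazin-2-yl on an aromatic carbon, with 1,2,4-oxadiazol-3-yl in place of pyrazin-2-yl on an aromatic carbon. All three measured steps exchange the group at this same place. Pyrimidin-2-yl in place of 1H-imidazol-2-yl gives a number 21 percentage points lower from compound 1 to compound 2 (beyond the scatter), pyrazin-2-yl in its place gives a number 18 percentage points lower from compound 1 to compound 3 (beyond the scatter), and pyrazin-2-yl in place of pyrimidin-2-yl gives a number 3 percentage points higher from compound 2 to compound 3 (within the scatter).

The last of these, which leaves the 1H-imidazol-2-yl group out of the comparison, is the closest guide, so little movement is expected. The estimated change is a number 2 percentage points higher from compound 3 to compound 4 (within the scatter). The entering ring is five-membered, like the 1H-imidazol-2-yl ring of compound 1 at 28%, so the range stays wider on the upper side. In this assay compound 4 is expected at 12%, within an estimated range from 3% to 27%.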

Compound 4, oral bioavailability: 5%
The estimate for compound 4 lay 7 percentage points above the measured number; the measured number falls inside the stated range.
By their numbers in this assay, from the lowest: compounds 4, 2 and 3 (each within the scatter of the next); then compound 1.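

At this place, on an aromatic carbon between two ring nitrogen atoms, a five-membered ring does not by itself match the 1H-imidazol-2-yl group: in this assay the 1,2,4-oxadiazol-3-yl group gives a number 23 percentage points lower from compound 1 to compound 4 (beyond the scatter) and so joins the lower group of compounds. Against the two six-membered rings it shows a number 5 percentage points lower from compound 3 to compound 4 (within the scatter) and a number 2 percentage points lower from compound 2 to compound 4 (within the scatter) in the same read-out, so ring size does not separate these three groups, and among the four compounds only compound 1 stands apart. Nothing shown accounts for the separation of compound 1 from the other three.

On these data alone, what remains open is how far the higher number of compound 1 depends on the 1H-imidazol-2-yl ring itself. A 1,2,4-triazol-3-yl ring, an N-methylimidazol-2-yl ring or a simple amine at this place could test that.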